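This account rests on a few compounds, and the source may have more. Where it says the series, first, only, none or still open, it means among the compounds named here.

Among the compounds with values here, compound 3, with structure `Oc1ccc(-c2cc(-c3ccccc3)cc(-c3cccs3)n2)cc1`, is one of three compounds measured in an assay on isolated protein for inhibition of DNA topoisomerase 1 (Homo sapiens), with a stated time of 30 min, tested at 100 uM; on this read-out higher numbers stand for a stronger effect at the one concentration tested and lower numbers for a weaker effect. Compound 3 gives 4.9%, the lowest of the three numbers. Compound 2, with structure `Oc1ccc(-c2cc(-c3ccccc3)cc(-c3ccccc3)n2)cc1`, gives 52.9%, and compound 1, with structure `Oc1cccc(-c2cc(-c3ccccc3)cc(-c3ccsc3)n2)c1`, gives 75.8%. The one step that connects two of these compounds, a number 48 percentage points lower from compound 2 to compound 3 (beyond the scatter), shows that putting thiophen-2-yl where phenyl stood cost a great deal of inhibition.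

Compound 4, with structure `Oc1ccc(-c2cc(-c3ccccc3)cc(-c3ccsc3)n2)cc1`, differs from compound 3 in a single place: thiophen-3-yl in place of thiophen-2-yl on an aromatic carbon. Within the data shown here, no measured step covers this exact swap. What the numbers do show is that compound 1 carries thiophen-3-yl and sits high, while compound 3 carries thiophen-2-yl and sits very low, although those two also differ in where the hydroxyl sits on the phenyl ring. Given that, a sizeable rise is expected, on the order of a number 45.1 percentage points higher from compound 3 to compound 4 (beyond the scatter). Compound 4 is therefore estimated at 50%, somewhere between 15% and 80%.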

Compound 4, a percentage reported as inhibition, at one concentration (the size of the read-out at that concentration, not a potency): 20.4%
Estimate against measurement, compound 4: 29.6 percentage points above; the measured number falls inside the stated range.
By their numbers in this assay, from the lowest: compound 3; then compound 4; then compound 2; then compound 1.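

With the 4-hydroxyphenyl group kept, changing thiophen-2-yl to thiophen-3-yl on the carbon next to the ring nitrogen recovers only part of the loss, with a number 15.5 percentage points higher from compound 3 to compound 4 (beyond the scatter) in this assay, while thiophen-3-yl in place of phenyl still gives a number 32.5 percentage points lower from compound 2 to compound 4 (beyond the scatter), so neither thiophene matches phenyl in this pair of series. The hydroxyl position can now be read on its own, and 4-hydroxyphenyl in place of 3-hydroxyphenyl gives a number 55.4 percentage points lower from compound 1 to compound 4 (beyond the scatter), a large step beside the modest one between the two thiophenes. Nothing measured here explains either change.

As far as these compounds go, because the hydroxyl step is read only with thiophen-3-yl, it remains open whether it holds with phenyl or thiophen-2-yl at this position. Also open, from the compounds shown here alone, is how an amine or a carboxylic acid in place of the hydroxyl would read.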